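Swapping Benzyloxy for Chloro on a Thiourea Series

This account rests on a few compounds, and the source may have more. Where it says the series, first, only, none or still open, it means among the compounds named here.

Three thiourea compounds that share a common core have been measured in an assay on membranes from brain for binding affinity to Lysophosphatidylserine lipase ABHD12 (Mus musculus), read by fluorescence, with a stated time of 20 min; on this read-out lower numbers stand for stronger inhibition and higher numbers for weaker inhibition. Compound 1, `FC(F)(F)c1cccnc1N1CCC(NC(=S)Nc2cccnc2)CC1`, reaches only the limit of the assay: in this assay compound 1 gives > 5000 nM, which is a limit rather than a number. Compound 2, `FC(F)(F)c1cnc(N2CCC(NC(=S)Nc3cccnc3)CC2)c(Cl)c1`, gives 1100 nM in this assay. Compound 3, `S=C(Nc1cccnc1)NC1CCN(c2cc(OCc3ccccc3)ccn2)CC1`, gives 2800 nM in this assay, the higher of the two numbers recorded, and its gap to compound 2 lies beyond the usual scatter of repeated measurements. Among the measured compounds shown here, of the three values, the one for compound 1 is a limit: the limit of > 5000 nM in this assay, at which 1 of the 3 values shown sits.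

Compound 4, `S=C(Nc1cccnc1)NC1CCN(c2cc(Cl)ccn2)CC1`, has not yet been measured. It differs from compound 3 in one place: chloro in place of benzyloxy on an aromatic carbon, at a position meta to a large group and opposite the ring nitrogen. For the measured compounds named here, no pair of measured compounds shows this exact change, so the direction of the step cannot be read from the data. With both recorded numbers already at the weak end, a modest further weakening is expected, amounting to an expected step of a 1.6-fold higher number from compound 3 to compound 4 (0.21 log units; within the scatter). Compound 4 is therefore estimated at 4500 nM, with a likely range from 1500 nM to 12000 nM, and a real chance that only a limit is reported.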

Compound 4, half-maximal inhibitory concentration: 2100 nM
For compound 4 the middle estimate is 2.1-fold (0.33 log units) above the measured one; low and high end bracket the measured number.
By their numbers in this assay, from the lowest: compounds 2, 4 and 3 (each within the scatter of the next, the first and the last beyond it). At a limit, above all of these: compound 1.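

Among the compounds shown here, this pair is the first in the set to differ in one place only, so a change at the position opposite the ring nitrogen can now be read directly in this assay: chloro in place of benzyloxy gives a 1.3-fold lower number from compound 3 to compound 4 (0.12 log units; within the scatter) and leaves the two compounds indistinguishable on this read-out. Benzyloxy carries 8 heavy atoms, including a six-membered aromatic ring of carbon only, while chloro is 1 heavy atom, so in this one pair the aromatic ring of benzyloxy is not needed to hold the value at this level. Nothing measured here points to a cause for this result.

Two groups at a single position say little about what the position will accept, and a methoxy group, an amine or a carboxylic acid there could give quite a different number. From the compounds shown here alone, compound 1 and compound 2, which carry trifluoromethyl, differ from compound 4 in more than one place, so the steps to them cannot be read and the effect of that group on this core stays unknown.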